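The source may report more compounds than this note shows. Statements on the series, on what has been measured and on what is new or still open speak of the compounds shown alone.

Measured so far in this series:

compound 1 `COC(=O)COc1cccc(/C=C/c2ccc3ccccc3n2)c1` — 2 mg/kg
compound 2 `O=C(O)CCCOc1cccc(/C=C/c2ccc3ccc(Cl)cc3n2)c1` — 0.5 mg/kg

In a functional assay on the whole organism for inhibition, with Rattus norvegicus as the target, with a stated time of 5 min (a higher number here means that more compound is needed for the effect, a lower number that less compound is needed), compound 1 gives 2 mg/kg, and compound 2 gives 0.5 mg/kg. Compound 2 stands lowest of the two numbers; compound 1 sits at a number beyond the scatter above it. Going by the values given here, the two compounds differ in several places at once (ester against acid, chain length, chloro on the fused ring), so no single structural change can be read from their values, and no one-place step is available here.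

Compound 3 `O=C(O)CCCOc1cccc(/C=C/c2ccc3cc(Cl)c(Cl)cc3n2)c1` is not yet measured. It differs from compound 2 by chloro in place of hydrogen on an aromatic carbon. The chloro enters on an aromatic carbon of the fused ring, ortho to a chloro group already present.

Among the compounds with values here, with no step of this kind measured, the direction is uncertain; a change of modest size, either none beyond the scatter or a mild lowering, is expected in this assay. Compound 3 is therefore estimated to give 0.4 mg/kg, with a range from 0.15 mg/kg to 1.2 mg/kg. The expected step is a 1.3-fold lower number from compound 2 to compound 3 (0.10 log units; within the scatter).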

Compound 3, dose for half-maximal effect: 0.5 mg/kg
Beside the measured number, compound 3's estimate is 1.3-fold (0.10 log units) below it; measured number inside the range.
By their numbers in this assay, from the lowest: compounds 2 and 3 (each within the scatter of the next); then compound 1.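

In this assay, chloro in place of hydrogen on an aromatic carbon of the fused ring, ortho to a chloro group, gives no change at the digits printed from compound 2 to compound 3 (within the scatter), the only one-place step among the compounds shown. This position therefore accepts a second chloro with no shift in the dose read-out, and compound 2 and compound 3 share one printed number, with compound 3 at 0.5 mg/kg in the same assay. No measurement shown speaks to a reason for this result.

Open, from the compounds shown here alone, is whether this position reads the same with a different group, such as a methoxy, a trifluoromethyl or a nitrile, and whether the chloro here would give the same number if the chloro group already present were replaced by hydrogen. Also open is how the core of compound 3 reads with a longer chain, or with an amide in place of the carboxylic acid, since the one-place step shown covers only the ring substitution.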